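Alkynyl chain isomers on the branched sugar of a cytosine nucleoside

The source may report more compounds than this note shows. Statements on the series, on what has been measured and on what is new or still open speak of the compounds shown alone.

Compound 1 `CC[C@@]1(O)[C@@H](CO)O[C@@H](n2ccc(N)nc2=O)[C@@H]1O`: 269000 nM in a functional assay on L1210 cells (Mus musculus), read by MTT assay; on this read-out higher numbers stand for weaker inhibition and lower numbers for stronger inhibition
Compound 2 `C#CC[C@@]1(O)[C@@H](CO)O[C@@H](n2ccc(N)nc2=O)[C@@H]1O`: in this assay a limit, > 350000 nM, and no number
Compound 3 `CC#C[C@@]1(O)[C@@H](CO)O[C@@H](n2ccc(N)nc2=O)[C@@H]1O`: not yet measured in this assay

On these data alone, compound 2 stands at the upper limit of this assay, (the limit of > 350000 nM in this assay, at which 1 of the 2 values shown sits), so its true value is unknown beyond that bound. Going by the values given here, compound 1 is the only measured compound with a number. Among the compounds with values here, the single measured step, an at least 1.3-fold higher number from compound 1 to compound 2 (0.11 log units; that floor lies within the scatter), lies within the scatter and at most shows compound 2 as no stronger than compound 1.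

Compound 3 differs from compound 2 by prop-1-yn-1-yl in place of propargyl on a saturated ring carbon. Within the data shown here, this change rearranges the same atoms within the three-carbon chain, and no measured step follows such a rearrangement; the step from compound 1 to compound 2 is the only guide and is itself not beyond the scatter. No step beyond the scatter is therefore expected in this assay, and compound 3 is expected to sit again at or near the limit. The expected step is a number no higher from compound 2 to compound 3 (the limit leaves the size open). Compound 3 is estimated at 350000 nM, within 150000 nM to 900000 nM.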

Compound 3, half-maximal inhibitory concentration: 24500 nM
Compound 3: middle estimate off by 14-fold (1.15 log units), on the high side; measured number below the stated range.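

In this assay, the saturated ring carbon proves sensitive to how a three-carbon chain is joined, which the earlier pair could not show: keeping the same atoms but placing prop-1-yn-1-yl in place of propargyl gives an at least 14-fold lower number from compound 2 to compound 3 (1.15 log units; beyond the scatter). Prop-1-yn-1-yl in place of ethyl gives an 11-fold lower number from compound 1 to compound 3 (1.04 log units; beyond the scatter), so a triple bond attached at this carbon goes with stronger inhibition in this small set, whereas the triple bond in propargyl does not. Compound 2 has only a limit, not a number: the limit of > 350000 nM in this assay, at which 1 of the 3 values shown sits.

On these data alone, it remains open whether an ethynyl group on the same ring carbon would keep this gain. Also open, as far as these compounds go, is whether a longer chain such as but-1-yn-1-yl, or a terminal amine on the chain, would keep or lose it.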